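The source may report more compounds than this note shows. Statements on the series, on what has been measured and on what is new or still open speak of the compounds shown alone.

Of the compounds shown here, three have numbers so far. Compound 1 `COC(=O)c1cccc(NC(=O)NC2CCN(C/C3=C/CCCCCC3)CC2)c1` gives 660 nM in a functional assay on CHO cells for antagonist activity at C-X-C chemokine receptor type 3 (Homo sapiens), read by GTPgammaS binding (a lower number here means a stronger inhibitor, a higher number a weaker inhibitor), compound 2 `O=C(Nc1ccc2ccccc2c1)NC1CCN(CCCc2ccccc2)CC1` gives 2200 nM, and compound 3 `CC1(C)[C@H]2CC=C(CN3CCC(NC(=O)Nc4cc(F)cc(F)c4)CC3)[C@@H]1C2` gives 171 nM. Compound 3 therefore has the lowest number of the three; compound 1 comes nearest and compound 2 lies furthest away, both gaps beyond the usual scatter. Compound 4 `CC1(C)[C@H]2CC=C(CN3CCC(NC(=O)Nc4cncc(Br)c4)CC3)[C@@H]1C2` differs from compound 3 in one place: 5-bromopyridin-3-yl in place of 3,5-difluorophenyl on an amide-type nitrogen. For the measured compounds named here, no measured pair shows a change of this kind, so the numbers at hand give no direct guide. A modest step toward a weaker inhibitor is expected, a 1.9-fold higher number from compound 3 to compound 4 (0.27 log units; within the scatter), though a result within the scatter would not surprise. Compound 4 is estimated at 320 nM, in the range 80 nM to 1300 nM.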

Compound 4, inhibition constant: 171 nM
Compound 4: middle estimate off by 1.9-fold (0.27 log units), on the high side; low and high end bracket the measured number.
By their numbers in this assay, from the lowest: compounds 3 and 4 (each within the scatter of the next); then compound 1; then compound 2.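

Measured in this assay the swap of 3,5-difluorophenyl for 5-bromopyridin-3-yl on the amide-type nitrogen gives no change at the digits printed from compound 3 to compound 4 (within the scatter) and so shows that this position can take a ring with a hetero atom and a bromine in place of an all-carbon ring with two fluorines. Nothing at hand explains why the two rings match. From the compounds shown here alone, the ring nitrogen and the bromine enter together, so what each does alone stays open. A ring bearing a carboxylic acid or an amine at this place would test how far this tolerance reaches.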